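Notes on the shared core and the step to compound 4

The source may hold more compounds than are shown below. What is called first, only, known or untested is meant among the compounds shown, and "the series" means these compounds.

The series shares one core, seen in compound 1 `COc1ccc(C2=C(c3cc(OC)c(OC)c(OC)c3)C(=O)C(O[SiH2]C(C)(C)C)C2)cc1OC(C)C`, compound 2 `COc1ccc(C2=C(c3cc(OC)c(OC)c(OC)c3)CC(O)C2=O)cc1[N+](=O)[O-]`, compound 3 `COc1ccc(C2=C(c3cc(OC)c(OC)c(OC)c3)C(=O)C(O)C2)cc1NC(=O)c1ccccc1` and the still unmeasured compound 4 `COc1ccc(C2=C(c3cc(OC)c(OC)c(OC)c3)C(=O)C(O)C2)cc1`. In an ADME assay on KB cells (Homo sapiens) for cytotoxicity, read by MTT assay, with a stated time of 72 h (a higher number here means a weaker inhibitor, a lower number a stronger inhibitor), compound 1 gives 7.5 ug/mL. For compound 2 this assay reports only a limit, > 100 ug/mL. For compound 3 this assay likewise reports only a limit, > 100 ug/mL. Compound 3 thus stands at the limit of > 100 ug/mL in this assay, at which 2 of the 3 values shown sit, without a number of its own. No pair among these three compounds differs in only one place, so no measured step can be drawn between them; of compounds 1 and 3 one can say only that the one has a number and the other a limit.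

Compound 4 differs from compound 3 by hydrogen in place of benzamido on an aromatic carbon. For the measured compounds named here, no step of this kind has been measured. In this assay compound 4 is expected to move off the limit toward a measured number, the estimated step being an at least 4.0-fold lower number from compound 3 to compound 4 (0.60 log units; beyond the scatter). This direction rests only on compound 1, which in this assay gives 7.5 ug/mL, and is held loosely. Compound 4 is estimated at 25 ug/mL, within a range from 4 ug/mL to 100 ug/mL, and a further limit cannot be excluded.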

Compound 4, half-maximal inhibitory concentration: < 1 ug/mL
Compound 4 ended at the assay's limit (the forecaster's own chance of this, stated with the estimate: 30%); at least 25-fold (1.39 log units) between middle value and limit.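

The one-place change at this position now has a measured size: in this assay, hydrogen in place of benzamido on an aromatic carbon, ortho to a methoxy group, gives an at least 100-fold lower number from compound 3 to compound 4 (2.00 log units; beyond the scatter). For the compounds shown here, this is the only single-place step so far, and it ties the benzamido at this position to the weak end of the scale and the unsubstituted position to the strong end. Neither end of the step is a number, however, and the true size may be greater than the step states, since compound 4 holds a limit and compound 3 holds another: the limit of > 100 ug/mL in this assay, at which 2 of the 4 values shown sit.

Going by these compounds, it remains open whether the whole benzamido is needed for this change or only part of it, and a free amine or an acetamido at the same aromatic carbon would separate the amide from its phenyl ring. On these data alone, compound 1 and compound 2 each differ from compound 4 in more than one place, so the separate contributions of a nitro or isopropoxy group at this position also remain open.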